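A few compounds are considered here, and "the series" means these few. Any claim that something is new, unique, unknown or untested is made for them only; others in the source may bear on it.

Compound 1 `COc1ccc(-c2nc3ccccc3s2)cc1OC` gives 42500 nM
Compound 2 `COc1ccc(-c2nc3cc(F)ccc3s2)cc1Br` gives 3450 nM
Compound 3 `COc1ccc(-c2nc3cc(F)ccc3s2)cc1OC` is not yet measured

In a functional assay on HCC 2998 cells (Homo sapiens) for antiproliferative activity (a higher number here means a weaker inhibitor of growth, a lower number a stronger inhibitor of growth), compound 2 holds the lower of the two numbers, and its gap to compound 1 lies beyond the scatter. Compound 3 carries methoxy in place of bromo on an aromatic carbon, ortho to a methoxy group (methoxy in place of bromo on an aromatic carbon). Within the data shown here, no measured pair isolates this change, so its size is poorly defined. A step towards a lower number, beyond the scatter, is expected in this assay, held with low confidence (a 12-fold lower number from compound 2 to compound 3 (1.06 log units; beyond the scatter)). Compound 3 is estimated at 300 nM (expected range 10 nM to 5000 nM).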

Compound 3, concentration for 50% growth inhibition: 0.25 nM
Compound 3: the middle estimate sits 1200-fold (3.08 log units) above what was measured, and the stated range ends above it.
By their numbers in this assay, from the lowest: compound 3; then compound 2; then compound 1.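

In this assay the place ortho to a methoxy group proves highly sensitive to what it carries, since methoxy in place of bromo on an aromatic carbon gives a 14000-fold lower number from compound 2 to compound 3 (4.14 log units; beyond the scatter) and the size of this change is now defined. Fluoro in place of hydrogen on an aromatic carbon also matters greatly, giving a 170000-fold lower number from compound 1 to compound 3 (5.23 log units; beyond the scatter) as a second single-place step. Nothing at hand accounts for either step.

From the compounds shown here alone, whether ethoxy, hydroxy or an amine at the same place would hold this level remains open. So does whether chloro or a nitrile could replace the fluoro.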